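Chain-end change in the diisopropylphenyl ketoamide

The source may hold more compounds than are shown below. What is called first, only, known or untested is meant among the compounds shown, and "the series" means these compounds.

Three compounds of the series have numbers in a functional assay on microsomes from intestine for inhibition of acyl-CoA:cholesterol acyltransferase (Oryctolagus cuniculus); a higher number here means a weaker inhibitor, a lower number a stronger inhibitor. Compound 1 `CCCCCCCCCCCC(=O)C(C)(C)C(=O)Nc1c(OC)cc(OC)cc1OC` gives 370 nM in this assay. Compound 2 `CCCCCCCCCCCC(=O)C(C)(C)C(=O)N(C)c1c(OC)cc(OC)cc1OC` reaches only the limit of > 1000 nM in this assay. Within the data shown here, the one single-point step among them, an at least 2.7-fold higher number from compound 1 to compound 2 (0.43 log units; beyond the scatter), is described as beyond the scatter; the related line the limit of > 1000 nM in this assay, at which 1 of the 3 values shown sits, records that one of the three values is a limit and not a number. Compound 3 `CC(C)c1cccc(C(C)C)c1NC(=O)CC(=O)CCCCCCCCCCO` gives 230 nM in this assay, which sits within the scatter of the number for compound 1, so no order between compound 3 and compound 1 can be read from them.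

Compound 4 `CCCCCCCCCCCCCCC(=O)CC(=O)Nc1c(C(C)C)cccc1C(C)C` has not yet been measured. It differs from compound 3 in butyl in place of hydroxy on a saturated chain carbon, ten or more bonds along the chain from a carbonyl carbon. Among the measured compounds shown here, none of the measured steps touches this part of the molecule: the only measured step concerns the amide nitrogen, not the far end of the chain, so it offers no guide to the size or direction of the change. With nothing to set a direction, the working expectation is a number near that of compound 3, with wide uncertainty. Compound 4 is therefore estimated at 150 nM in this assay, between 50 nM and 500 nM, which means an expected step of a 1.5-fold lower number from compound 3 to compound 4 (0.19 log units; within the scatter).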

Compound 4, half-maximal inhibitory concentration: 24 nM
Beside the measured number, compound 4's estimate is 6.3-fold (0.80 log units) above it; measured number outside the range, below it.
By their numbers in this assay, from the lowest: compound 4; then compounds 3 and 1 (each within the scatter of the next). At a limit, above all of these: compound 2.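

Among these compounds, the far end of the chain is not a silent position: butyl in place of hydroxy on a saturated chain carbon, ten or more bonds along the chain from a carbonyl carbon, gives a 9.6-fold lower number from compound 3 to compound 4 (0.98 log units; beyond the scatter) in this assay and is the first measured step away from the amide nitrogen. This one step changes two things at once, as the hydroxy leaves with its hydrogen-bond donor and acceptor while the chain end gains carbon atoms, so the compounds shown cannot assign the shift to either change alone. Nothing at hand bears on why the number moves at this position.

Still open, going by these compounds, is whether the hydroxy or the added carbon matters more, a question that a chain of the same length ending in methoxy, or a shorter or longer unsubstituted chain on the same core, would bear on directly. Also open, on these data alone, is how a carboxylic acid or an amine at the chain end would read in this assay, and whether the same change carries over to the core of compound 1.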